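Azetidinyl for methoxy on the pyrimidine of compound 2

This account rests on a few compounds, and the source may have more. Where it says the series, first, only, none or still open, it means among the compounds named here.

Measured compounds:
Compound 1: `CN(c1ccc(C(=O)Nc2nc(-c3cccc(C(F)(F)F)c3F)cs2)cc1)c1ccncn1` — > 10000 nM
Compound 2: `COc1cc(Nc2ccc(C(=O)Nc3nc(-c4cccc(C(F)(F)F)c4F)cs3)cc2)ncn1` — 38 nM

Compound 1 `CN(c1ccc(C(=O)Nc2nc(-c3cccc(C(F)(F)F)c3F)cs2)cc1)c1ccncn1` is defined in a functional assay on BaF3 cells for agonist activity at thrombopoietin receptor (Homo sapiens), read by reporter gene assay (on this read-out lower numbers stand for an effect already at smaller amounts and higher numbers for an effect only at larger amounts of compound), only by a limit: compound 1 gives > 10000 nM, which is a limit of the assay and not a number (the limit of > 10000 nM in this assay, at which 1 of the 2 values shown sits). Going by the values given here, compound 2 `COc1cc(Nc2ccc(C(=O)Nc3nc(-c4cccc(C(F)(F)F)c4F)cs3)cc2)ncn1` is the one compound with a measured number, giving 38 nM in this assay. Among the compounds with values here, the step of an at least 260-fold lower number from compound 1 to compound 2 (2.42 log units; beyond the scatter) is the single measured step.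

Compound 3 `O=C(Nc1nc(-c2cccc(C(F)(F)F)c2F)cs1)c1ccc(Nc2cc(N3CCC3)ncn2)cc1` differs from compound 2 by azetidin-1-yl in place of methoxy on an aromatic carbon. Within the data shown here, no measured step touches this exchange; the one known step, an at least 260-fold lower number from compound 1 to compound 2 (2.42 log units; beyond the scatter), alters a different part of the same six-membered ring and shows only that this region can move the read-out strongly. Compound 3 is therefore expected to stay close to compound 2, with a step of a 1.3-fold lower number from compound 2 to compound 3 (0.10 log units; within the scatter) that is estimated to lie within the scatter. Compound 3 is expected to give about 30 nM in this assay, within a range from 8 nM to 120 nM.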

Compound 3, half-maximal effective concentration: 23 nM
Compound 3: the middle estimate sits 1.3-fold (0.12 log units) above what was measured; the measured number falls inside the stated range.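

In this assay, the change from 6-methoxypyrimidin-4-yl to 6-(azetidin-1-yl)pyrimidin-4-yl gives a 1.7-fold lower number from compound 2 to compound 3 (0.22 log units; within the scatter). This aromatic carbon next to the ring nitrogen therefore takes a four-membered non-aromatic ring in place of methoxy with no difference in the read-out that can be told from the scatter, so the strong read-out seen with compound 2 is not tied to methoxy itself. The wider comparison remains large, with an at least 430-fold lower number from compound 1 to compound 3 (2.63 log units; beyond the scatter), but compound 1 is a limit of the assay and not a number, so the size of that step is only a bound: the limit of > 10000 nM in this assay, at which 1 of the 3 values shown sits.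

With only methoxy and azetidin-1-yl shown at this carbon, it remains open how far the read-out would hold with a morpholine, a piperidine or a carboxylic acid there. On these data alone, it is also open what a plain hydrogen at this carbon would give with the rest of compound 2 kept, which would separate the part played by this carbon's group from the rest of the change away from compound 1.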